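The source may hold more compounds than are shown below. What is called first, only, known or untested is meant among the compounds shown, and "the series" means these compounds.

Among the compounds with values here, in a functional assay for inhibition, with Homo sapiens as the target (on this read-out lower numbers stand for stronger inhibition and higher numbers for weaker inhibition), compound 1 `CC#CCC(C)[C@H](O)/C=C/[C@H]1[C@H](O)C[C@]2(C#CCCCI)C/C(=C/CCCC(=O)O)C[C@H]12` gives 200 nM and compound 2 `CC#CCC(C)[C@H](O)/C=C/[C@H]1[C@H](O)C[C@]2(C#CCCCI)C/C(=C\CCCC(=O)O)C[C@H]12` gives 5 nM; compound 2 therefore holds the lower of the two numbers, and the single measured step is a 40-fold lower number from compound 1 to compound 2 (1.60 log units; beyond the scatter), which turns only on the drawn geometry of one double bond (the fact that one of compounds 1 and 2 is drawn with a defined configuration and the other without, at the place where they differ). Compound 3 `CC#CCC(C)[C@H](O)/C=C/[C@H]1[C@H](O)C[C@]2(CCC#CCCCO)C/C(=C\CCCC(=O)O)C[C@H]12` keeps the geometry of compound 2 and differs from it by 7-hydroxyhept-3-yn-1-yl in place of 5-iodopent-1-yn-1-yl on a saturated ring carbon. Within the data shown here, no measured step touches that ring carbon, so nothing measured bears directly on the new group; a small loss is expected, a 3.0-fold higher number from compound 2 to compound 3 (0.48 log units; beyond the scatter). Compound 3 is estimated at 15 nM, range 3 nM to 70 nM.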

Compound 3, half-maximal inhibitory concentration: 400 nM
Estimate against measurement, compound 3: 27-fold (1.43 log units) below, outside the stated range (above it).
By their numbers in this assay, from the lowest: compound 2; then compounds 1 and 3 (each within the scatter of the next).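

With the geometry of compound 2 held, this saturated ring carbon proves sensitive to what it carries: 7-hydroxyhept-3-yn-1-yl in place of 5-iodopent-1-yn-1-yl gives an 80-fold higher number from compound 2 to compound 3 (1.90 log units; beyond the scatter). The change replaces the iodine with a hydroxy group, lengthens the chain and moves the triple bond away from the ring all at once, so the step cannot be assigned to any one of these. Nothing on hand bears on the origin of this step.

Open, on these data alone, is which of those features carries the loss. Also open, as far as these compounds go, is how an amine or a carboxylic acid at the chain end would read out.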